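This account rests on a few compounds, and the source may have more. Where it says the series, first, only, none or still open, it means among the compounds named here.

Measured compounds in a functional assay on cells for agonist activity at D(4) dopamine receptor (Homo sapiens), read by TR-FRET and cAMP accumulation, with a stated time of 30 min; a lower number here means a smaller maximal response, a higher number a larger maximal response:

compound 1, `CCc1cccc(NC(=O)CN2CCN(c3ccc(Cl)cn3)CC2)c1` — compound 1 gives "not active" (no number reported)
compound 2, `CCc1cccc(NC(=O)CN2CCN(c3ccccn3)CC2)c1` — compound 2 gives 58%
compound 3, `Cc1cccc(NC(=O)CN2CCN(c3ncccn3)CC2)c1` — compound 3 gives 64.6%

Compound 1 stands apart from compounds 2 and 3 in that no single number was obtained for it in this assay: it is reported as not active, so there is no value from which a step to a neighbour can be read. Compounds 2 and 3 both carry a 3-alkylphenyl amide and both return a measurable largest response in this assay, whereas compound 1, which differs from them in the aryl on the piperazine, does not.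

Compound 4, `O=C(CN1CCN(c2ccc(Cl)cn2)CC1)Nc1cncnc1`, keeps the piperazine aryl of compound 1 and changes only the amide end. The difference is pyrimidin-5-yl in place of 3-ethylphenyl on an amide-type nitrogen. No measured pair shows this kind of change, so its size and direction cannot be taken from the data shown. Given that compound 1 itself gives "not active" (no number reported), the starting point for compound 4 is a compound without a measurable response, and no other measured compound shares its amide end.

Compound 4 is expected to give a low largest response in this assay, estimated at 20% with a range of 0% to 55%, with a real chance that it, too, comes back without a number.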

Compound 4, largest response reached (Emax), in percent of the reference or control that the assay uses: "not active" (no number reported)
Compound 4 has no reported number here; the estimate stays without a comparison.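

In this assay compound 1 gives "not active" (no number reported) and compound 4 gives "not active" (no number reported) so no step can be read between them. No measured evidence bears on this result. The compounds shown leave open what pyrimidin-5-yl in place of 3-ethylphenyl does in a compound with a numerical response, such as compound 2.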